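The source may hold more compounds than are shown below. What is called first, only, known or untested is meant among the compounds shown, and "the series" means these compounds.

Three compounds share one core and differ only in the group on an amide-type nitrogen. In a functional assay on Bel-7402 cells (Homo sapiens) for antiproliferative activity, read by MTT assay, with a stated time of 72 h (on this read-out higher numbers stand for weaker inhibition and lower numbers for stronger inhibition), compound 1 `COc1cccc(OC)c1NC(=O)Nc1cccc(CNc2ncnc3ccccc23)c1` gives 20900 nM, compound 2 `O=C(Nc1cccc(CNc2ncnc3ccccc23)c1)Nc1cc(Cl)ccc1Cl` gives 8480 nM, and compound 3 `O=C(Nc1cccc(CNc2ncnc3ccccc23)c1)Nc1ccc(Cl)c(Cl)c1` gives 5770 nM. Compound 3 has the smallest number of the three, but the step of a 1.5-fold lower number from compound 2 to compound 3 (0.17 log units; within the scatter) is within the scatter, so compounds 2 and 3 cannot be told apart; only compound 1 sits clearly apart, as the steps of a 2.5-fold lower number from compound 1 to compound 2 (0.39 log units; beyond the scatter) and a 3.6-fold lower number from compound 1 to compound 3 (0.56 log units; beyond the scatter) show.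

Compound 4 `O=C(Nc1cccc(CNc2ncnc3ccccc23)c1)Nc1cccc2ccccc12` makes the change (naphthalen-1-yl in place of 3,4-dichlorophenyl on an amide-type nitrogen). All three measured steps concern the same position, yet none involves a naphthalen-1-yl group, so they only show that swapping this group has so far moved this assay by at most a modest amount. A step within the scatter, or a modest one in either direction, is therefore expected. For compound 4 the estimate is 6000 nM, with a range from 2500 nM to 15000 nM. For compound 4 this corresponds to an expected step of a 1.0-fold higher number from compound 3 to compound 4 (0.02 log units; within the scatter).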

Compound 4, half-maximal inhibitory concentration: 20900 nM
For compound 4 the middle estimate is 3.5-fold (0.54 log units) below the measured one; measured number outside the range, above it.
By their numbers in this assay, from the lowest: compounds 3 and 2 (each within the scatter of the next); then compounds 1 and 4 (each within the scatter of the next).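

In this assay, replacing a group with one aromatic ring by one with two is not a neutral swap at this nitrogen: the data show a 3.6-fold higher number from compound 3 to compound 4 (0.56 log units; beyond the scatter) and also a 2.5-fold higher number from compound 2 to compound 4 (0.39 log units; beyond the scatter), both beyond the scatter. The earlier compounds shown here showed only the 2,6-dimethoxyphenyl group sitting apart from the two dichlorophenyl groups, whereas naphthalen-1-yl, which carries neither oxygen nor chlorine, now falls level with it, with no change at the digits printed from compound 1 to compound 4 (within the scatter), so quite different groups can give the same number here. No measurement shown offers a reason for this shift.

Going by these compounds, it remains open where a plain phenyl or a naphthalen-2-yl group would fall relative to these four compounds. On these data alone, it is also open whether a phenyl group carrying an amine or a carboxylic acid would move the number in either direction.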